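The compounds below may be only part of what the source reports. "The series", "measured", "known", "first", "only" and "open" are said of these compounds alone.

The measured compounds:
Compound 1 `CN(CC1=CC[C@H]2C[C@@H]1C2(C)C)Cc1ccc(-c2ccccc2F)cc1`: in an assay on HEK293 cells for displacement of a labelled ligand from C-X-C chemokine receptor type 3 (Homo sapiens) (a lower number here means a stronger inhibitor, a higher number a weaker inhibitor), compound 1 gives > 316 nM, which is a limit of the assay and not a number.
Compound 2 `CN(CC1=CC[C@H]2C[C@@H]1C2(C)C)Cc1ccc(-c2cccc(C(F)(F)F)c2)cc1`: in this assay compound 2 gives > 316 nM, again a limit of the assay.
Compound 3 `CC(=O)c1cccc(-c2ccc(CN(C)CC3=CC[C@H]4C[C@@H]3C4(C)C)cc2)c1`: in this assay compound 3 gives > 316 nM, also a limit.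

Compound 3 thus stands at the limit of > 316 nM in this assay, at which 3 of the 3 values shown sit, and nothing in the numbers sets it apart from the other two. The change to compound 4 `CN(CC1=CC[C@H]2C[C@@H]1C2(C)C)Cc1ccc(-c2cccc(O)c2)cc1` is hydroxy in place of acetyl on an aromatic carbon. The steps that touch the same position, a step that the two limits leave unreadable from compound 1 to compound 3 and a step that the two limits leave unreadable from compound 2 to compound 3, are unreadable, so neither a size nor a direction can be drawn from them. With every value shown at the limit, compound 4 is expected to stay weak, and the step that the limit leaves unreadable from compound 3 to compound 4 is expected to be none that could be read. Compound 4 is estimated at 1000 nM, with a range from 200 nM to 5000 nM.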

Compound 4, inhibition constant: > 316 nM
Compound 4: no number, only a limit; the forecaster's own chance of this, stated with the estimate: 75%; the middle value lies beyond the limit too.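

No step from compound 4 to compound 1, compound 2 or compound 3 can be read, because all four compounds sit at a limit, not a number: the limit of > 316 nM in this assay, at which 4 of the 4 values shown sit.

The compounds shown leave open how far each lies past that limit and whether their groups differ at all.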